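Fluoro for chloro on the shared core

This account rests on a few compounds, and the source may have more. Where it says the series, first, only, none or still open, it means among the compounds named here.

Measured so far, all in an assay on isolated protein for inhibition of Calpain-1 catalytic subunit (Sus scrofa); a lower number here means a stronger inhibitor, a higher number a weaker inhibitor:
compound 1 `O=C(O)/C(S)=C/c1c[nH]c2ccc(Cl)cc12` gives 50 nM
compound 2 `O=C(O)/C(S)=C/c1c[nH]c2c(Cl)cccc12` gives 90 nM
compound 3 `O=C(O)/C(S)=C/c1c[nH]c2cc(Br)ccc12` gives 90 nM

Compound 2 is level with compound 3 at the digits shown, and the two together give the highest numbers of the three. Compound 1 gives a lower number, but the gap from compound 2 is within the scatter, so no order can be read among the three in this assay.

Compound 4 `O=C(O)/C(S)=C/c1c[nH]c2c(F)cccc12` differs from compound 2 in one place: fluoro in place of chloro on an aromatic carbon. Among the measured compounds shown here, no measured pair shows what this swap does here. The step is expected to be small, a 1.2-fold higher number from compound 2 to compound 4 (0.09 log units; within the scatter), with no direction beyond the scatter. Compound 4 is estimated at 110 nM, between 50 nM and 250 nM.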

Compound 4, half-maximal inhibitory concentration: 110 nM
Estimate against measurement, compound 4: no gap at the digits printed; the range from low to high includes it.
By their numbers in this assay, from the lowest: compounds 1, 2, 3 and 4 (each within the scatter of the next, the first and the last beyond it).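

In this assay, among the compounds shown here, this is the first readable swap at this place on the shared core: fluoro in place of chloro gives a 1.2-fold higher number from compound 2 to compound 4 (0.09 log units; within the scatter). On this aromatic carbon, ortho to a fused ring, the two halogens cannot be told apart, a reading that rests on this one pair. Nothing measured here bears on the reason for this result.

Still open, from the compounds shown here alone, is whether an amine or a methoxy group at this place would give a number beyond the scatter. Also open, going by these compounds, is how the same swap reads on the carbons carrying chloro in compound 1 and bromo in compound 3.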